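This account rests on a few compounds, and the source may have more. Where it says the series, first, only, none or still open, it means among the compounds named here.

Compound 1 `CC(C)CSc1nc(N)nc2c1ncn2/C=C1/CC1(CO)CO`: > 300000 nM
Compound 2 `CCCCCOc1nc(N)nc2c1ncn2/C=C1/CC1(CO)CO`: 259000 nM

In an ADME assay on HFF cells (Homo sapiens) for cytotoxicity, with a stated time of 8 days (on this read-out higher numbers stand for lower toxicity in this test and lower numbers for higher toxicity in this test), compound 1 gives only a limit, > 300000 nM. In this assay compound 2 gives 259000 nM, the only number shown in this pair. Going by the values given here, the one measured step, an at least 1.1-fold lower number from compound 1 to compound 2 (0.06 log units; that floor lies within the scatter), lies within the scatter. Compound 3 `Nc1nc(SCc2ccccc2)c2ncn(/C=C3/CC3(CO)CO)c2n1` differs from compound 2 by benzylsulfanyl in place of pentyloxy on an aromatic carbon. Among the compounds with values here, only that one step bears on this change, and it was within the scatter, so no step beyond the scatter is expected in this assay for compound 3. Compound 3 is therefore estimated at 270000 nM, with a range of 110000 nM to 650000 nM. The expected step is a 1.0-fold higher number from compound 2 to compound 3 (0.02 log units; within the scatter).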

Compound 3, half-maximal cytotoxic concentration: > 300000 nM
Compound 3: no number, only a limit (the forecaster's own chance of this, stated with the estimate: 40%); middle value at least 1.1-fold (0.04 log units) from the limit.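

In this assay compound 3 gives a limit, not a number. Benzylsulfanyl in place of pentyloxy gives an at least 1.1-fold higher number from compound 2 to compound 3 (0.06 log units; that floor lies within the scatter) and shows that a six-membered aromatic ring of carbon only, carried on this sulfur-linked group, brings no step beyond the scatter at this position. The step between compound 1 and compound 3 cannot be read. Values in this test gather at one point: the limit of > 300000 nM in this assay, at which 2 of the 3 values shown sit.

Still open, as far as these compounds go, is whether an amine or a carboxylic acid at this position would bring a step beyond the scatter.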